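The source may hold more compounds than are shown below. What is called first, only, known or untested is meant among the compounds shown, and "the series" means these compounds.

In an ADME assay (liver) for metabolic stability, with Liver microsome (Rattus norvegicus) as the target, read by LC-MS, using microsomes and NADPH, with a stated time of 10 min, tested at 0.3 mM (a lower number here means slower removal, a higher number faster removal of the compound), compound 1 (`Cn1c(-c2cccnc2)nc2ccc(F)cc21`) gives 30 mL/min/kg. Compound 2 (`Fc1cc2nc(-c3cccnc3)n(C3CC3)c2cc1F`) gives < 20 mL/min/kg and this is a limit of the assay, not a number. Compound 3 (`Fc1ccc2nc(-c3cccnc3)n(C3CC3)c2c1`) keeps the core of compound 2 with a single change hydrogen in place of fluoro on an aromatic carbon that puts hydrogen in place of fluoro on an aromatic carbon. Going by the values given here, no measured pair shows this change alone, and the expectation is only a small rise in clearance, perhaps no greater than the usual scatter. The expected step is an at least 1.1-fold higher number from compound 2 to compound 3 (0.04 log units; that floor lies within the scatter). For compound 3 the estimated clearance is 22 mL/min/kg, with a range from 12 mL/min/kg to 40 mL/min/kg.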

Compound 3, clearance: 28 mL/min/kg
Estimate against measurement, compound 3: 1.3-fold (0.10 log units) below; the measured number falls inside the stated range.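

Hydrogen in place of fluoro on this aromatic carbon, seen here as a single change for the first time, gives an at least 1.4-fold higher number from compound 2 to compound 3 (0.14 log units; that floor lies within the scatter). The value of compound 2 is a limit of the assay and not a number, so this step has only a floor and its true size stays unknown: the limit of < 20 mL/min/kg in this assay, at which 1 of the 3 values shown sits.
Cyclopropyl in place of methyl on the aromatic nitrogen gives a 1.1-fold lower number from compound 1 to compound 3 (0.03 log units; within the scatter), so this swap shows no clear effect on clearance.

From the compounds shown here alone, whether chlorine or an amine on this aromatic carbon would shift clearance remains open. So does the effect of an ethyl chain on the aromatic nitrogen.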